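The source may report more compounds than this note shows. Statements on the series, on what has been measured and on what is new or still open speak of the compounds shown alone.

Compound 1 `COc1cc(-c2cc(C(=O)/C=C/c3ccccc3)nc3cc(-c4ccccc4)nn23)cc(OC)c1OC`: in a functional assay on A549 cells (Homo sapiens) for antiproliferative activity, read by MTT assay, with a stated time of 24 h (a lower number here means a stronger inhibitor, a higher number a weaker inhibitor), compound 1 gives 18000 nM.
Compound 2 `COc1cc(-c2cc(/C=C/C(=O)c3ccccc3)nc3cc(-c4ccccc4)nn23)cc(OC)c1OC`: in this assay compound 2 gives 18200 nM.

Compound 2 has the higher of the two numbers, but the gap to compound 1 lies within the scatter. Compound 3 `COc1cc(-c2cc(C(=O)/C=C/c3ccc(C)cc3)nc3cc(-c4ccccc4)nn23)cc(OC)c1OC` differs from compound 2 by (2-(4-methylphenyl)ethenyl)carbonyl in place of 2-benzoylethenyl on an aromatic carbon. Among the measured compounds shown here, one measured step bears on this: a 1.0-fold higher number from compound 1 to compound 2 (0.00 log units; within the scatter), which already exchanges the two arrangements of carbonyl and double bond and shows no change beyond the scatter. For the measured compounds named here, the added methyl has no measured counterpart. Compound 3 is therefore expected to stay close to compound 2, a step of a 1.0-fold lower number from compound 2 to compound 3 (0.00 log units; within the scatter), with an estimate of 18000 nM (range 8000 nM to 40000 nM).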

Compound 3, half-maximal inhibitory concentration: 20000 nM
Compound 3: the middle estimate sits 1.1-fold (0.05 log units) below what was measured; the range from low to high includes it.
By their numbers in this assay, from the lowest: compounds 1, 2 and 3 (each within the scatter of the next).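

In this assay, methyl in place of hydrogen on an aromatic carbon gives a 1.1-fold higher number from compound 1 to compound 3 (0.05 log units; within the scatter) and so adds no change beyond the scatter. Putting (2-(4-methylphenyl)ethenyl)carbonyl in place of 2-benzoylethenyl gives a 1.1-fold higher number from compound 2 to compound 3 (0.04 log units; within the scatter) and likewise leaves the two compounds within the scatter, so this position has so far tolerated both changes. No measurement here explains why these numbers stay so close.

The compounds shown leave open whether a group quite unlike methyl on that benzene ring, such as an amine or a carboxylic acid, would move the number. They also leave open what a simple amide would do in place of the whole side chain.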